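A Nitro Group Added to Two Related Cores

The source may report more compounds than this note shows. Statements on the series, on what has been measured and on what is new or still open speak of the compounds shown alone.

Compound 1 `COc1c(N2CC(C)OC(C)C2)c(F)cc2c(=O)c(C(=O)O)cn(C3CC3)c12` was tested in an ADME assay on Vero cells (Chlorocebus sabaeus) for cytotoxicity, read by MTT assay, with a stated time of 72 h (a lower number here means a stronger inhibitor, a higher number a weaker inhibitor), where compound 1 gives 160000 nM. Compound 3 `COc1c(N2CC(C)OC(C)C2)c(F)c([N+](=O)[O-])c2c(=O)c(C(=O)O)cn(C3CC3)c12` carries one change relative to compound 1, (nitro in place of hydrogen on an aromatic carbon), and the outcome was a 1.1-fold lower number from compound 1 to compound 3 (0.05 log units; within the scatter). In this assay compound 3 gives 144000 nM. Compound 2 `COc1c(N2CCn3cc(C(=O)O)nc3C2)c(F)cc2c(=O)c(C(=O)O)cn(C3CC3)c12` has a different core; how the two cores differ is not broken down here. In this assay compound 2 gives 141000 nM, a number that sits within the scatter of both compound 1 and compound 3, so no order among the three can be read. Compound 4 `COc1c(N2CCn3cc(C(=O)O)nc3C2)c(F)c([N+](=O)[O-])c2c(=O)c(C(=O)O)cn(C3CC3)c12` stands to compound 2 as compound 3 stands to compound 1: nitro in place of hydrogen on an aromatic carbon. The surroundings of the change are not identical, since in compound 1 the new group sits meta to a 2,6-dimethylmorpholin-4-yl group, whereas in compound 2 it sits meta to a large group, so this is the same kind of change rather than the same change. Because the earlier step was a 1.1-fold lower number from compound 1 to compound 3 (0.05 log units; within the scatter), compound 4 is expected to give a step of a 1.1-fold lower number from compound 2 to compound 4 (0.04 log units; within the scatter). Compound 4 is therefore estimated at 130000 nM, expected to fall between 70000 nM and 260000 nM.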

Compound 4, half-maximal inhibitory concentration: 128000 nM
The estimate for compound 4 lay 1.0-fold (0.01 log units) above the measured number; low and high end bracket the measured number.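

In this assay the nitro group in place of hydrogen gives a 1.1-fold lower number from compound 2 to compound 4 (0.04 log units; within the scatter) and so behaves on this core as it did on the first one: the same change on two cores in this assay, a 1.1-fold lower number (0.05 log units; within the scatter) from compound 1 to compound 3 and a 1.1-fold lower number (0.04 log units; within the scatter) from compound 2 to compound 4, 1.0-fold (0.00 log units) apart, within the scatter of two such steps.

The change therefore carries over from one core to the other in a modest sense: on neither core does it move the number beyond the usual scatter of repeat measurements. This does not show that the nitro group has a real effect of a fixed size, since two steps this small would agree even if the group did nothing at all, and two cores cannot speak for the whole series.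

Still open, from the compounds shown here alone, is whether a different group on that same aromatic carbon, such as an amine or a nitrile, would also leave the number within the scatter. Also open, going by these compounds, is whether the nitro step would stay this small on a core with another group, such as an ethoxy group, in place of the methoxy group.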